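The source may hold more compounds than are shown below. What is called first, only, known or untested is meant among the compounds shown, and "the series" means these compounds.

Of the compounds shown here, three built on one shared core have been tested in a functional assay on LNCaP cells (Homo sapiens) for antiproliferative activity, read by WST assay, with a stated time of 3 days; on this read-out lower numbers stand for stronger inhibition and higher numbers for weaker inhibition. Compound 1 `CCOc1c(-c2cc(OC)c(OC)c(OC)c2)oc2ccccc2c1=O` gives 5400 nM and stands lowest of the three numbers. Compound 2 `CCCC(C)Oc1c(-c2cc(OC)c(OC)c(OC)c2)oc2ccccc2c1=O` gives 15100 nM, and compound 3 `CCN(CC)CCCCCOc1c(-c2cc(OC)c(OC)c(OC)c2)oc2ccccc2c1=O` gives 10000 nM. Putting propyl in place of hydrogen on a saturated chain carbon gave a 2.8-fold higher number from compound 1 to compound 2 (0.45 log units; beyond the scatter). Putting 3-(diethylamino)propyl in place of hydrogen on a saturated chain carbon gave a 1.9-fold higher number from compound 1 to compound 3 (0.27 log units; within the scatter). Comparing the two longer chains directly, there was a 1.5-fold lower number from compound 2 to compound 3 (0.18 log units; within the scatter).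

Compound 4 `CCCN(CCC)CCCOc1c(-c2cc(OC)c(OC)c(OC)c2)oc2ccccc2c1=O` has not yet been measured. It differs from compound 1 by (dipropylamino)methyl in place of hydrogen on a saturated chain carbon, two bonds along the chain from an oxygen on an aromatic ring. Among the compounds with values here, the measured step that resembles it most is the one to compound 3, where the chain also carries an amine and which gave a 1.9-fold higher number from compound 1 to compound 3 (0.27 log units; within the scatter), a move within the scatter. A small rise at most is therefore expected. Compound 4 is expected to give about 9000 nM in this assay, with a range from 3500 nM to 25000 nM. The expected step is a 1.7-fold higher number from compound 1 to compound 4 (0.22 log units; within the scatter).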

Compound 4, half-maximal inhibitory concentration: 17900 nM
The estimate for compound 4 lay 2.0-fold (0.30 log units) below the measured number; the range from low to high includes it.
By their numbers in this assay, from the lowest: compounds 1, 3, 2 and 4 (each within the scatter of the next, the first and the last beyond it).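

In this assay, changing the ethoxy of compound 1 to 3-(dipropylamino)propoxy gives a 3.3-fold higher number from compound 1 to compound 4 (0.52 log units; beyond the scatter) and so, unlike the chain with a diethylamino group in compound 3, this amine-bearing chain moves the number beyond the scatter. Yet the dipropylamino chain cannot be separated from that diethylamino chain, with a 1.8-fold higher number from compound 3 to compound 4 (0.25 log units; within the scatter) and within the scatter. Nor can it be separated from the amine-free 1-methylbutyl group, with a 1.2-fold higher number from compound 2 to compound 4 (0.07 log units; within the scatter) and again within the scatter, so an amine on the chain makes no readable difference among these three longer groups.

Still open, on these data alone, is whether a chain carrying morpholine or a carboxylic acid in place of the dipropylamino group would behave the same way. No evidence is available to explain any of these steps.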